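The source may hold more compounds than are shown below. What is called first, only, known or untested is meant among the compounds shown, and "the series" means these compounds.

Values in an ADME assay on MDBK cells (Bos taurus) for cytotoxicity, read by MTT assay; on this read-out lower numbers stand for higher toxicity in this test and higher numbers for lower toxicity in this test:
- compound 1 `COc1ccc(OCCCCCCN2C[C@H](O)[C@@H](O)[C@H](O)[C@H]2CO)cc1`: > 500000 nM (a limit of the assay)
- compound 2 `OC[C@@H]1[C@@H](O)[C@H](O)[C@@H](O)CN1CCCCCCOc1cc(Cl)ccc1Cl`: 320000 nM
- compound 3 `OC[C@@H]1[C@@H](O)[C@H](O)[C@@H](O)CN1CCC#CCCOc1cc(F)ccc1F`: > 500000 nM (a limit of the assay)

Not yet measured: compound 4 `OC[C@@H]1[C@@H](O)[C@H](O)[C@@H](O)CN1CCCCCCOc1c(F)cc(F)cc1F`.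

Compound 2 stands alone with an actual number, 320000 nM. The other two results are limits, not numbers: the limit of > 500000 nM in this assay, at which 2 of the 3 values shown sit.

The next comparison is with compound 4, where the change is 2,4,6-trifluorophenyl in place of 2,5-dichlorophenyl on an oxygen on a saturated carbon. In words, 2,4,6-trifluorophenyl replaces 2,5-dichlorophenyl on an oxygen on a saturated carbon, and the rest of the structure stays the same.

Going by the values given here, only one measured step changes this same place: an at least 1.5-fold lower number from compound 1 to compound 2 (0.19 log units; that floor lies within the scatter). It therefore gives no firm size or direction to carry over. Among the compounds with values here, compound 3 has no measured step to compound 2 or compound 4, so it adds only its limit.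

On this basis, no change beyond the scatter is expected in this assay, and a result reported only as a limit is quite possible. The expected step is a 1.3-fold higher number from compound 2 to compound 4 (0.10 log units; within the scatter). For compound 4 the estimated value is 400000 nM, with an expected range of 200000 nM to 800000 nM.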

Compound 4, half-maximal cytotoxic concentration: > 500000 nM
Compound 4: a limit, no number; the forecaster's own chance of this, stated with the estimate: 55%; at least 1.2-fold (0.09 log units) between middle value and limit.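

In this assay compound 4 gives > 500000 nM, a limit of the assay and not a number. The change to 2,4,6-trifluorophenyl on an oxygen on a saturated carbon gives an at least 1.5-fold higher number from compound 2 to compound 4 (0.19 log units; that floor lies within the scatter), so this position now has a second step out of compound 2's 2,5-dichlorophenyl, and again only a floor within the scatter can be read, with no firm size or direction. At this place 4-methoxyphenyl and 2,4,6-trifluorophenyl both leave the read-out at a limit, while 2,5-dichlorophenyl alone gives a number, and that difference rests only on floors within the scatter: the limit of > 500000 nM in this assay, at which 3 of the 4 values shown sit.

Compound 1 and compound 4 both stand as limits, so the step between them cannot be read. Compound 2 gives 320000 nM. Still open, from the compounds shown here alone, is whether an amine or a carboxylic acid on the phenyl ring, or a longer chain to the shared core, would bring a change clearly beyond the scatter from that value.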